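Paw edema series: aryl hydrazones on a shared core

This account rests on a few compounds, and the source may have more. Where it says the series, first, only, none or still open, it means among the compounds named here.

Measured so far:
Compound 1 `O=C(N/N=C/c1ccc(Cl)cc1)c1cccnc1Nc1cccc(C(F)(F)F)c1`: 67.2%
Compound 2 `O=C(N/N=C/c1cccc(O)c1)c1cccnc1Nc1cccc(C(F)(F)F)c1`: 63.8%
Compound 3 `COc1cccc(/C=N/NC(=O)c2cccnc2Nc2cccc(C(F)(F)F)c2)c1`: 58.8%

All three were read in a functional assay on the whole organism (strain Wistar) for inhibition, with Rattus norvegicus as the target, read by paw edema, with a stated time of 1 h, at a dose of 10 mg/kg by the intraperitoneal route; on this read-out lower numbers stand for less inhibition and higher numbers for more inhibition at the one dose given (going by the name of the read-out). Compound 3 gives the lowest of the three numbers, but its nearest neighbour is compound 2, with a number 5 percentage points lower from compound 2 to compound 3 (within the scatter), and the furthest is compound 1, with a number 8.4 percentage points lower from compound 1 to compound 3 (within the scatter); both gaps lie within the scatter, so no order can be drawn among the three. The remaining measured step, a number 3.4 percentage points lower from compound 1 to compound 2 (within the scatter), also stays within the scatter.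

Compound 4 `COc1ccc(/C=N/NC(=O)c2cccnc2Nc2cccc(C(F)(F)F)c2)cc1` has not yet been measured. It differs from compound 3 as follows: 4-methoxyphenyl in place of 3-methoxyphenyl on a carbon with a double bond to nitrogen. Among the compounds with values here, no measured step bears directly on this change: the three steps so far exchange the whole aryl group, or hydrogen for methyl on the ring oxygen, and each of them stayed within the scatter. On that footing nothing beyond the scatter is expected here, and the step expected in this assay is correspondingly small, a number 2.2 percentage points higher from compound 3 to compound 4 (within the scatter). Compound 4 is therefore estimated at 61%, with an expected range from 50% to 72%.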

Compound 4, a percentage reported as inhibition, in the whole organism at one dose (the size of the read-out at that dose, not a potency): 59.4%
Compound 4: middle estimate off by 1.6 percentage points, on the high side; measured number inside the range.
By their numbers in this assay, from the lowest: compounds 3, 4, 2 and 1 (each within the scatter of the next).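

In this assay, within the data shown here, the exchange of 4-methoxyphenyl for 3-methoxyphenyl on a carbon with a double bond to nitrogen gives a number 0.6 percentage points higher from compound 3 to compound 4 (within the scatter) and is the first step that keeps the same atoms and changes only how they are joined, so at this dose the read-out does not separate these two methoxyphenyl groups. Two further steps extend this to other substituents on the aryl group: 4-methoxyphenyl in place of 3-hydroxyphenyl gives a number 4.4 percentage points lower from compound 2 to compound 4 (within the scatter) and methoxy in place of chloro gives a number 7.8 percentage points lower from compound 1 to compound 4 (within the scatter), so all the aryl groups shown at this place remain within the scatter of one another. Nothing available offers an explanation for the size of these steps.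

From the compounds shown here alone, whether an amine or a carboxylic acid on the aryl ring, or a longer chain in place of the methyl on the ring oxygen, would give a step beyond the scatter in this assay stays open. Going by these compounds, with one dose and one time point, it also stays open whether these compounds would separate under other conditions.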